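The source may hold more compounds than are shown below. What is called first, only, known or untested is meant among the compounds shown, and "the series" means these compounds.

In a functional assay on HT-29 cells (Homo sapiens) for inhibition, read by luminescence and CellTiter-Glo, with a stated time of 24 h (a lower number here means that less compound is needed, a higher number that more compound is needed for the effect), compound 1 (`CCCn1nc(C(=O)N[C@H]2COc3ccccc3N(C)C2=S)nc1Cc1ccccc1`), with propyl on an aromatic nitrogen, gives 288 nM. Compound 2 (`CN1C(=S)[C@@H](NC(=O)c2nc(Cc3ccccc3)n(CCCCCC#N)n2)COc2ccccc21`) gives 3830 nM, and compound 3 (`CN1C(=S)[C@@H](NC(=O)c2nc(Cc3ccccc3)n(C3CCCCC3)n2)COc2ccccc21`) gives 4000 nM. Compound 3 thus sits level with compound 2 at the high end of the numbers, with a 1.0-fold higher number from compound 2 to compound 3 (0.02 log units; within the scatter). Both stand well apart from compound 1, with a 13-fold higher number from compound 1 to compound 2 (1.12 log units; beyond the scatter) and a 14-fold higher number from compound 1 to compound 3 (1.14 log units; beyond the scatter). Compound 4 (`CN1C(=S)[C@@H](NC(=O)c2nc(Cc3ccccc3)n(C3CCN(C(=O)OC(C)(C)C)C3)n2)COc2ccccc21`) alters the same aromatic nitrogen substituent of compound 3: a group of 12 heavy atoms (9 carbon, 1 nitrogen, 2 oxygen; one five-membered non-aromatic ring with 1 hetero atom) in place of a group of 6 heavy atoms (6 carbon; one six-membered non-aromatic ring of carbon only), on an aromatic nitrogen. The closest guide is the replacement of 5-cyanopentyl by cyclohexyl, a 1.0-fold higher number from compound 2 to compound 3 (0.02 log units; within the scatter), so no change beyond the scatter is expected. The expected step is a 1.1-fold higher number from compound 3 to compound 4 (0.05 log units; within the scatter). The estimate for compound 4 is 4500 nM, with an expected range from 1200 nM to 16000 nM.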

Compound 4, half-maximal effective concentration: > 10000 nM
Compound 4: only a limit was reported; the forecaster's own chance of this, stated with the estimate: 10%; at least 2.2-fold (0.34 log units) between middle value and limit.
By their numbers in this assay, from the lowest: compound 1; then compounds 2 and 3 (each within the scatter of the next). At a limit, above all of these: compound 4.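

In this assay the result for compound 4 is a limit and not a number: the limit of > 10000 nM in this assay, at which 1 of the 4 values shown sits. Even so, an at least 2.5-fold higher number from compound 3 to compound 4 (0.39 log units; beyond the scatter) and an at least 2.6-fold higher number from compound 2 to compound 4 (0.41 log units; beyond the scatter) both lie beyond the scatter, so this aromatic nitrogen separates large groups that cyclohexyl and 5-cyanopentyl alone, level with each other, did not. Against propyl, the gap reaches an at least 34-fold higher number from compound 1 to compound 4 (1.54 log units; beyond the scatter). The compounds shown leave open how far past its limit compound 4 lies. They also leave open whether the lower number seen with propyl extends to a shorter chain such as ethyl, or how a free amine on the five-membered ring would read.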